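From 2-methylphenyl to 3-chloro-4-methoxyphenyl: one swap, one estimate

The compounds below may be only part of what the source reports. "The series", "measured", "known", "first", "only" and "open" are said of these compounds alone.

compound 1 (`Cn1ncc2cc(Nc3ncnn4ccc(CN5CCC(N)CC5)c34)ccc21`): "not active" (no number reported)
compound 2 (`Cc1ccccc1Nc1ncnn2ccc(CN3CCC(N)CC3)c12`): 3300 nM

Among the measured compounds shown here, in a functional assay on NCI-N87 cells (Homo sapiens) for antiproliferative activity (a higher number here means a weaker inhibitor, a lower number a stronger inhibitor), compound 2 gives 3300 nM and this is the only number so far. Compound 1 is reported as "not active" (no number reported) with no number attached, so compound 2 has no measured value to be ranked against. Compound 3 (`COc1ccc(Nc2ncnn3ccc(CN4CCC(N)CC4)c23)cc1Cl`) keeps the shared core and changes one group: 3-chloro-4-methoxyphenyl in place of 2-methylphenyl on a nitrogen on an aromatic ring. For the measured compounds named here, no measured pair shows what such a swap does, so any forecast is loose. The expected 2.2-fold lower number from compound 2 to compound 3 (0.34 log units; beyond the scatter) is a modest move towards a stronger inhibitor, only slightly beyond the scatter. Compound 1, at "not active" (no number reported) in the same test, shows that a result without a number remains possible. Compound 3 is estimated in this assay at 1500 nM (expected range 300 nM to 8000 nM).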

Compound 3, half-maximal inhibitory concentration: 1210 nM
Estimate against measurement, compound 3: 1.2-fold (0.09 log units) above; measured number inside the range.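

In this assay, among the compounds shown here, putting 3-chloro-4-methoxyphenyl in place of 2-methylphenyl on a nitrogen on an aromatic ring gives a 2.7-fold lower number from compound 2 to compound 3 (0.44 log units; beyond the scatter) as the first measured step at this position. It shows that the number here responds to the group on that nitrogen: the step is modest but beyond the usual scatter, and it points towards a stronger inhibitor, with compound 3 at 1210 nM in this test. No measurement shown gives a reason for the step.

Because the swap changes the whole aromatic group at once, the effects of its chlorine, its methoxy group and the lost methyl cannot be separated. For the compounds shown here, how a phenyl ring carrying an amine or a carboxylic acid would behave at this position also stays open, and compound 1, which has no number, offers no step to compare.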